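Demethylation of an aromatic methoxy in a cyclic peptide

The compounds below may be only part of what the source reports. "The series", "measured", "known", "first", "only" and "open" are said of these compounds alone.

Four cyclic peptides share a large macrocyclic core and were examined in a functional assay on P388 cells (Mus musculus) for cytotoxicity; a higher number here means a weaker inhibitor, a lower number a stronger inhibitor. Compound 1 `COc1ccc(C[C@H]2C(=O)N[C@@H](C)C(=O)N(C)[C@H]3Cc4ccc(cc4)Oc4cc(ccc4OC)C[C@@H](C(=O)N[C@H](C)C(=O)N[C@@H](CCC(=O)O)C(=O)N2C)N(C)C3=O)cc1` gives 219 nM. Compound 2 `COC(=O)CC[C@@H]1NC(=O)[C@@H](C)NC(=O)[C@@H]2Cc3ccc(OC)c(c3)Oc3ccc(cc3)C[C@@H](C(=O)N2C)N(C)C(=O)[C@H](C)NC(=O)[C@H](Cc2ccc(OC)cc2)N(C)C1=O` gives 58.9 nM. The two differ in one spot: hydrogen in place of methyl on an oxygen next to a carbonyl group. That change produces a 3.7-fold higher number from compound 2 to compound 1 (0.57 log units; beyond the scatter), a modest weakening.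

Compound 3 `COc1ccc(C[C@H]2C(=S)N[C@@H](C)C(=O)N(C)[C@H]3Cc4ccc(cc4)Oc4cc(ccc4OC)C[C@@H](C(=O)N[C@H](C)C(=O)N[C@@H](C)C(=O)N2C)N(C)C3=O)cc1` gives 0.741 nM, the lowest number of the three measured compounds, and its steps to compound 2 and compound 1 are both beyond the scatter. The difference between the core of compound 3 and the core of compound 2 is not broken down here.

Compound 4 `COc1ccc(C[C@H]2C(=S)N[C@@H](C)C(=O)N(C)[C@H]3Cc4ccc(cc4)Oc4cc(ccc4O)C[C@@H](C(=O)N[C@H](C)C(=O)N[C@@H](C)C(=O)N2C)N(C)C3=O)cc1` has not yet been measured. It differs from compound 3 in one spot: hydrogen in place of methyl on an oxygen on an aromatic ring. Within the data shown here, this is the same kind of change as the one from compound 2 to compound 1, a methyl leaving an oxygen and a hydrogen taking its place, but the surroundings differ: in the earlier pair the oxygen sits next to a carbonyl group, while in compound 3 the oxygen sits on an aromatic ring. Among the measured compounds shown here, the only guide is the earlier pair, where the step from compound 2 to compound 1 was modest because a 3.7-fold higher number from compound 2 to compound 1 (0.57 log units; beyond the scatter) lies beyond the scatter but not far. A similarly modest weakening is expected here, read against the value of compound 3, so the expected step is a 2.4-fold higher number from compound 3 to compound 4 (0.39 log units; beyond the scatter). Compound 4 is accordingly estimated to give about 1.8 nM, with a range from 0.5 nM to 7 nM.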

Compound 4, half-maximal inhibitory concentration: 1.15 nM
Compound 4: middle estimate off by 1.6-fold (0.19 log units), on the high side, and the stated range covers the measured number.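

In this assay, replacing the methyl on the oxygen on the aromatic ring with hydrogen gives a 1.6-fold higher number from compound 3 to compound 4 (0.19 log units; within the scatter), so the two values cannot be told apart in this measurement. Set beside the earlier case, in which the oxygen sits next to a carbonyl group, the step on this second core cannot be separated from the first: the same change on two cores in this assay, a 3.7-fold higher number (0.57 log units; beyond the scatter) from compound 2 to compound 1 and a 1.6-fold higher number (0.19 log units; within the scatter) from compound 3 to compound 4, 2.4-fold (0.38 log units) apart, within the scatter of two such steps. Among these compounds, this rests on only two pairs, with the oxygen in a different setting in each, and it does not show that the change would have a fixed size on every core.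

The compounds shown leave open what other groups would do on that same oxygen, for example a longer chain such as ethoxy, or what an amine would do in place of the hydroxy. From the compounds shown here alone, it also remains open how methoxy to hydroxy at this place would read on the core of compound 2, which carries the same methoxy, and that pair would test the change itself on a second core.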